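Removing the Substituent on the Ring Amide Nitrogen

This account rests on a few compounds, and the source may have more. Where it says the series, first, only, none or still open, it means among the compounds named here.

Of the compounds shown here, three built on one shared core have been tested in an assay on isolated protein for inhibition of MAP/microtubule affinity-regulating kinase 3 (Homo sapiens), read by HTRF; on this read-out lower numbers stand for stronger inhibition and higher numbers for weaker inhibition. Compound 2 `CC1(C)C(=O)N(C2CCCCC2)c2nc(Nc3cccc(N4CCNCC4)c3)ncc21` gives 14 nM. Compound 3 `CC1(C)C(=O)N(c2ccccc2)c2nc(Nc3ccccc3)ncc21` gives 2800 nM, the higher of the two numbers on record, with compound 2 the lower. Compound 1 `Cn1cc(N2C(=O)c3nc(Nc4ccccc4)ncc3C2(C)C)cn1` gives > 30000 nM, which is the limit of > 30000 nM in this assay, at which 1 of the 3 values shown sits, and so a limit rather than a number.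

Compound 4 `CC1(C)C(=O)Nc2nc(Nc3ccccc3)ncc21` is compound 3 with one change, hydrogen in place of phenyl on an amide-type nitrogen in a ring. For the measured compounds named here, no measured pair differs in exactly this way, so the size of the step can only be judged from the fact that every measured compound carries some group at that nitrogen, and that compound 1, with a different group there, reaches only a limit. The expectation is that compound 4 binds more weakly than compound 3, as a step of a 4.3-fold higher number from compound 3 to compound 4 (0.63 log units; beyond the scatter) in this assay. Compound 4 is therefore estimated at 12000 nM in this assay, with a range from 2500 nM to 50000 nM, and a fair chance that only a limit is reported.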

Compound 4, half-maximal inhibitory concentration: 12800 nM
For compound 4 the middle estimate is 1.1-fold (0.03 log units) below the measured one; low and high end bracket the measured number.
By their numbers in this assay, from the lowest: compound 2; then compound 3; then compound 4. At a limit, above all of these: compound 1.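

With a 4.6-fold higher number from compound 3 to compound 4 (0.66 log units; beyond the scatter) in this assay, this position has its first reading in which nothing else on the molecule changes. The phenyl, a group of 6 heavy atoms, contributes only modestly here: with just a hydrogen on the amide-type nitrogen, compound 4 still gives 12800 nM as a true number and not a limit. Nothing on record explains why the step has this size.

The compounds shown leave open how a methyl group, an ethyl chain or a benzyl group on this nitrogen would compare with hydrogen and phenyl. Also open, as far as these compounds go, is whether the step would keep its size in the company of the other groups of compound 2, which differs from compound 3 in more than one place.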